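Isobutyl on the Glycine Carbon: Cytotoxicity of Three Quinones

The source may report more compounds than this note shows. Statements on the series, on what has been measured and on what is new or still open speak of the compounds shown alone.

The measured compounds and their values:
compound 1 `CC(C)(C)C1=CC(=O)C=C(NCC(=O)O)C1=O` — > 200000 nM
compound 2 `CC1=CCC[C@H]2[C@](C)(CC3=CC(=O)C=C(N[C@@H](CC(C)C)C(=O)O)C3=O)[C@@H](C)CC[C@]12C` — 73400 nM
compound 3 `CC1=CCC[C@H]2[C@](C)(CC3=CC(=O)C=C(NCC(=O)O)C3=O)[C@@H](C)CC[C@]12C` — 183000 nM

Of the compounds shown here, three have been measured in an ADME assay on MRC5 cells (Homo sapiens) for cytotoxicity, read by MTT assay, with a stated time of 72 h; a higher number here means a weaker inhibitor, a lower number a stronger inhibitor. Compound 1 gives only a limit of the assay, the value > 200000 nM, which is the limit of > 200000 nM in this assay, at which 1 of the 3 values shown sits. Compound 3 gives 183000 nM in this assay. Compound 2 gives 73400 nM in this assay, and the change from compound 3 to compound 2 is isobutyl in place of hydrogen on a saturated chain carbon bound to an amine nitrogen and a carbonyl carbon; the step it made is a 2.5-fold lower number from compound 3 to compound 2 (0.40 log units; beyond the scatter). How the core of compound 1 differs from the core of compound 3 is not broken down here.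

Compound 4 `CC(C)C[C@H](NC1=CC(=O)C=C(C(C)(C)C)C1=O)C(=O)O` has not yet been measured. It differs from compound 1 by isobutyl in place of hydrogen on a saturated chain carbon bound to an amine nitrogen and a carbonyl carbon. The place is the same, word for word, as in the change from compound 3 to compound 2, so this is the same change made on the core of compound 1. A step of about the size seen from compound 3 to compound 2 is expected, but it starts from a limit, because compound 1 sits at the limit of > 200000 nM in this assay, at which 1 of the 3 values shown sits, so the number for compound 4 may again be a limit rather than a value. The expected step is a number no higher from compound 1 to compound 4 (the limit leaves the size open). Compound 4 is expected near 200000 nM, with a range from 80000 nM to 500000 nM.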

Compound 4, half-maximal inhibitory concentration: > 200000 nM
Compound 4: a limit, no number; the forecaster's own chance of this, stated with the estimate: 55%; the middle value sits exactly at the limit.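

In this assay compound 4 gives > 200000 nM, which is a limit of the assay and not a number. Compound 1 and compound 4 both stand at a limit, so no step between them can be read: the limit of > 200000 nM in this assay, at which 2 of the 4 values shown sit.

The compounds shown leave open whether isobutyl in place of hydrogen lowers the number on the core of compound 1, as it did from compound 3 to compound 2.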